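Methyl on the amide-type nitrogen of compound 2

This account rests on a few compounds, and the source may have more. Where it says the series, first, only, none or still open, it means among the compounds named here.

Two compounds of this series carry numbers in a functional assay on cells (T-cell, Mus musculus) for inhibition; on this read-out higher numbers stand for weaker inhibition and lower numbers for stronger inhibition. Compound 1 `COc1cc(/C=C/C(=O)Nc2ccc3c(c2)COC3=O)ccc1OC(C)=O` gives 136 nM in this assay. Compound 2 `O=C(Nc1ccccc1)Nc1ccc2c(c1)COC2=O` gives 7090 nM in this assay, the highest of the two numbers, and the gap to compound 1 lies beyond the scatter of repeated measurements. Going by the values given here, no step between measured compounds that differ in a single place is available, so the direction of any single change is not yet anchored by data.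

Compound 3 `CN(C(=O)Nc1ccc2c(c1)COC2=O)c1ccccc1` is not yet measured. It differs from compound 2 in one place: methyl in place of hydrogen on an amide-type nitrogen. The hydrogen on that amide-type nitrogen is lost and a single carbon takes its place; nothing else in the shared core changes.

With no measured step of this kind in hand, a small move toward weaker inhibition, or none beyond the scatter, is the expectation for the step of a 2.0-fold higher number from compound 2 to compound 3 (0.30 log units; within the scatter). Compound 3 is therefore expected to give about 14000 nM in this assay. Compound 3 is estimated to fall within a range running from 4000 nM to 50000 nM.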

Compound 3, half-maximal inhibitory concentration: > 100000 nM
Compound 3 ended at the assay's limit (the forecaster's own chance of this, stated with the estimate: 15%); at least 7.1-fold (0.85 log units) between middle value and limit.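

In this assay, going by these compounds alone, methyl in place of hydrogen on the amide-type nitrogen gives an at least 14-fold higher number from compound 2 to compound 3 (1.14 log units; beyond the scatter), the first step that rests on two measured compounds and the first sign that this position is sensitive to change. A single carbon on a nitrogen whose other neighbours are an aromatic carbon and a carbonyl carbon is enough to leave a step beyond the scatter, so the amide hydrogen of compound 2 cannot be replaced by methyl here without a large loss of inhibition on this read-out. Compound 3 gives > 100000 nM, which is a limit of the assay and not a number, so the step fixes only a minimum size and its true size stays unknown: the limit of > 100000 nM in this assay, at which 1 of the 3 values shown sits.

The compounds shown do not separate the loss of the hydrogen from the presence of the added carbon, and a larger group such as ethyl or acetyl on this nitrogen would test that only in part. From the compounds shown here alone, whether methyl on the amide-type nitrogen of compound 1 would produce a comparable step also remains open.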